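Changing the Aromatic Ring on the Sulfonyl Sulfur

The source may hold more compounds than are shown below. What is called first, only, known or untested is meant among the compounds shown, and "the series" means these compounds.

Compound 1 `CCN(Cc1ccccc1)C(=O)C1CCN(S(=O)(=O)c2c[nH]cn2)CC1` was tested in a functional assay on CHO cells for positive allosteric modulation of muscarinic acetylcholine receptor M5 (Homo sapiens), read by calcium flux; a lower number here means that less compound is needed, a higher number that more compound is needed for the effect. In this assay compound 1 reaches only the limit of > 10000 nM, so no number is known for it. Compound 2 `CCN(Cc1ccccc1)C(=O)C1CCN(S(=O)(=O)c2c(C)noc2C)CC1` carries a 3,5-dimethyl-1,2-oxazol-4-yl in place of the 1H-imidazol-4-yl on the sulfonyl sulfur. In this assay compound 2 likewise gives only the limit of > 10000 nM. The step between the two is a step that the two limits leave unreadable from compound 1 to compound 2, and both values sit at the limit of > 10000 nM in this assay, at which 2 of the 2 values shown sit. Compound 2 thus stands where every value shown so far stands: at a limit rather than at a number.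

Compound 3 `CCN(Cc1ccccc1)C(=O)C1CCN(S(=O)(=O)c2ccccn2)CC1` continues with pyridin-2-yl in place of 3,5-dimethyl-1,2-oxazol-4-yl on a sulfonyl sulfur. No measured step bears on this change; the one step shown is unreadable. With nothing to read, the expectation for compound 3 rests on the two limits alone, and compound 3 is expected to give about 8000 nM in this assay, within a range from 1500 nM to 30000 nM. The step that this estimate means is an at least 1.2-fold lower number from compound 2 to compound 3 (0.09 log units; that floor lies within the scatter), with no direction that stands out beyond the scatter.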

Compound 3, half-maximal effective concentration: > 10000 nM
Compound 3: a limit, no number; the forecaster's own chance of this, stated with the estimate: 70%; middle value at least 1.2-fold (0.09 log units) away from the limit.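

In this assay compound 3 gives > 10000 nM as well, which is a limit and not a number. Among the compounds shown here, with only limits in hand, no step among compound 1, compound 2 and compound 3 can be read. The compounds shown leave open how far apart these three truly lie, and which group on the sulfonyl sulfur, if any, would give a number rather than a limit.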